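Extending the amide methyl of compound 1 with a hydroxyl group

The compounds below may be only part of what the source reports. "The series", "measured", "known", "first", "only" and "open" are said of these compounds alone.

In a functional assay on LNCaP cells (Homo sapiens) for antiproliferative activity (on this read-out higher numbers stand for weaker inhibition and lower numbers for stronger inhibition), compound 1 `CNC(=O)C[C@@H]1C[C@@H](c2ccc(Cl)c(Cl)c2)[C@H](NC(=O)c2cc(-c3c(Cl)cnn3C)c(Cl)o2)CN1` gives 40 nM and holds the lowest number of the three measured compounds; compound 2 `Cn1ncc(Cl)c1-c1cc(C(=O)N[C@@H]2CN[C@H](CCN3CCCCC3)C[C@H]2c2ccc(Cl)c(Cl)c2)oc1Cl` gives 1780 nM and compound 3 `Cn1ncc(Cl)c1-c1cc(C(=O)N[C@@H]2CN[C@H](CC(=O)NCC(O)CO)C[C@H]2c2ccc(Cl)c(Cl)c2)oc1Cl` gives 660 nM. The step to compound 4 `Cn1ncc(Cl)c1-c1cc(C(=O)N[C@@H]2CN[C@H](CC(=O)NCCO)C[C@H]2c2ccc(Cl)c(Cl)c2)oc1Cl` changes compound 1 in one place: hydroxymethyl in place of hydrogen on a saturated chain carbon bound to an amide-type nitrogen. Going by the values given here, the measured step that bears on it is the one from compound 1 to compound 3, made at the same place, which gave a 17-fold higher number from compound 1 to compound 3 (1.22 log units; beyond the scatter). The change in compound 4 is a smaller extension of the same kind, so a weakening beyond the scatter is expected in this assay, though of lesser size than a 17-fold higher number from compound 1 to compound 3 (1.22 log units; beyond the scatter). Compound 4 is therefore estimated at 250 nM, with a range from 80 nM to 800 nM, a step of a 6.3-fold higher number from compound 1 to compound 4 (0.80 log units; beyond the scatter).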

Compound 4, half-maximal inhibitory concentration: 40 nM
The estimate for compound 4 lay 6.3-fold (0.80 log units) above the measured number; the measured number lies below the stated range.
By their numbers in this assay, from the lowest: compounds 1 and 4 (each within the scatter of the next); then compound 3; then compound 2.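

In this assay, hydroxymethyl on the saturated chain carbon bound to an amide-type nitrogen gives no change at the digits printed from compound 1 to compound 4 (within the scatter), so this position accepts the 2-hydroxyethyl group without a measurable loss. Removing the further hydroxymethyl gives a 17-fold lower number from compound 3 to compound 4 (1.22 log units; beyond the scatter), which ties the weakening seen earlier to the 2,3-dihydroxypropyl group rather than to any hydroxyl-bearing extension. (2-Hydroxyethyl)carbamoyl in place of (piperidin-1-yl)methyl gives a 45-fold lower number from compound 2 to compound 4 (1.65 log units; beyond the scatter).

No evidence here explains the difference between these two extensions. From the compounds shown here alone, whether a 3-hydroxypropyl chain, an amine or a carboxylic acid would be accepted at this position remains open.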